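The source may hold more compounds than are shown below. What is called first, only, known or untested is meant among the compounds shown, and "the series" means these compounds.

Measured in a functional assay on A2058 cells (Homo sapiens) for antiproliferative activity, read by luminescence and CellTiter-Glo, with a stated time of 96 h; a lower number here means a stronger inhibitor, a higher number a weaker inhibitor:
Compound 1 `O=C(Nc1ccc(F)cc1)c1n[nH]cc1NC(=O)c1c(F)ccc(-c2cccc(O)c2)c1F`: "not determined" (no result reported)
Compound 2 `O=C(Nc1ccc(F)cc1)c1n[nH]cc1NC(=O)c1c(F)ccc(-c2ccncc2)c1F`: 2940 nM
Compound 3 `O=C(Nc1ccc(F)cc1)c1n[nH]cc1NC(=O)c1c(F)ccc(-c2ccc(F)nc2)c1F`: 6310 nM

Only two of these compounds have a number, and compound 3 holds the higher one at 6310 nM. The nearest neighbour is compound 2 at 2940 nM, while compound 1 offers no number to compare.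

The next compound to be tested is compound 4 `O=C(Nc1ccc(F)cc1)c1n[nH]cc1NC(=O)c1c(F)ccc(-c2ccccc2)c1F`. It differs from compound 3 by one change: phenyl in place of 6-fluoropyridin-3-yl on an aromatic carbon. The rest of the structure is shared.

Going by the values given here, only one measured step bears on this change, a 2.1-fold higher number from compound 2 to compound 3 (0.33 log units; beyond the scatter), which is modest and just beyond the scatter. Among the compounds with values here, that step swaps one pyridine-type group for another, and no measured compound with a number carries phenyl, so it gives only a rough guide to size. On that evidence, a small move towards a lower number in this assay is expected, probably not clearly beyond the scatter. The estimated change is a 1.6-fold lower number from compound 3 to compound 4 (0.20 log units; within the scatter). Compound 4 is expected at about 4000 nM. The estimated range for compound 4 runs from 1500 nM to 10000 nM.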

Compound 4, half-maximal inhibitory concentration: 2370 nM
Beside the measured number, compound 4's estimate is 1.7-fold (0.23 log units) above it, within the range that was stated.
By their numbers in this assay, from the lowest: compounds 4 and 2 (each within the scatter of the next); then compound 3.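

In this assay, phenyl in place of 6-fluoropyridin-3-yl on this aromatic carbon, ortho to one fluoro group and para to another, gives a 2.7-fold lower number from compound 3 to compound 4 (0.43 log units; beyond the scatter), a modest step that lies beyond the scatter. Phenyl in place of pyridin-4-yl gives a 1.2-fold lower number from compound 2 to compound 4 (0.09 log units; within the scatter), which lies within the scatter, so the ring of carbon only and the pyridin-4-yl ring cannot be told apart here, and compound 3 alone stands apart from the other two, as the weakest of the three with a number. Nothing measured here offers an explanation for either step.

The compounds shown do not separate the part played by the ring nitrogen from that of the fluorine in 6-fluoropyridin-3-yl, a question that pyridin-3-yl without fluorine or a 4-fluorophenyl group would bear on. Going by these compounds, compound 1 has no number, so its hydroxyl on the phenyl ring cannot be read, and it remains open how an amine, a carboxylic acid or a longer chain on this carbon would behave.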